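The compounds below may be only part of what the source reports. "The series", "measured", "known", "first", "only" and "open" are said of these compounds alone.

Among the compounds with values here, in a functional assay on MDA-MB-436 cells (Homo sapiens) for antiproliferative activity, read by MTT assay, with a stated time of 48 h (on this read-out lower numbers stand for stronger inhibition and higher numbers for weaker inhibition), compound 1 `CN1CCN(c2ccc(-c3cc4c(N5CCN(S(=O)(=O)N6CCCCC6)CC5)ncnc4s3)cc2)CC1` gives 7570 nM and compound 2 `CN1CCN(c2ccc(-c3cc4c(N5CCN(C(=O)Nc6ccccc6)CC5)ncnc4s3)cc2)CC1` gives 7090 nM as the only numbers so far. These two values lie within the scatter of each other, so compound 2 stands level with compound 1. Compound 3 `CN1CCN(c2ccc(-c3cc4c(N5CCN(C(=O)Nc6ccc(C#N)cc6)CC5)ncnc4s3)cc2)CC1` differs from compound 2 by cyano in place of hydrogen on an aromatic carbon, para to a large group (cyano in place of hydrogen on an aromatic carbon), which turns phenylcarbamoyl into (4-cyanophenyl)carbamoyl. Within the data shown here, the only measured step is a 1.1-fold lower number from compound 1 to compound 2 (0.03 log units; within the scatter) and it stayed within the scatter. That step exchanged the whole group on an amine nitrogen in a ring and left the phenyl untested, so it bears only loosely here. In this assay a small step is therefore expected, with no firm direction and possibly nothing beyond the scatter. The expected step is a 1.2-fold lower number from compound 2 to compound 3 (0.07 log units; within the scatter) on this estimate. For compound 3 the estimated value is 6000 nM with an expected range from 2000 nM to 18000 nM on present data.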

Compound 3, half-maximal inhibitory concentration: 5010 nM
Compound 3: the middle estimate sits 1.2-fold (0.08 log units) above what was measured, and the stated range covers the measured number.
By their numbers in this assay, from the lowest: compounds 3, 2 and 1 (each within the scatter of the next).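

In this assay, cyano in place of hydrogen on an aromatic carbon, para to a large group, gives a 1.4-fold lower number from compound 2 to compound 3 (0.15 log units; within the scatter) and so does not shift the read-out beyond the scatter at this place on the phenyl. The exchange on the amine nitrogen in a ring, now tested with the cyano present as (4-cyanophenyl)carbamoyl against (piperidin-1-yl)sulfonyl, gives a 1.5-fold lower number from compound 1 to compound 3 (0.18 log units; within the scatter) and likewise stays within the scatter. No outside data are available to explain the size of either step.

From the compounds shown here alone, whether an amine, a carboxylic acid or a methoxy group at this same place on the phenyl would give a step beyond the scatter remains open. Also open, going by these compounds, is whether a longer chain in place of the phenyl on the carbamoyl would separate from compound 2.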